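Trimethoxy styryl lactam: expected growth inhibition on glioma cells

The source may report more compounds than this note shows. Statements on the series, on what has been measured and on what is new or still open speak of the compounds shown alone.

Measured so far:
compound 1, `COc1cc(/C=C/C2CC(=O)C=CO2)cc(OC)c1OC`, 102 uM in a functional assay on U-251 cells (Homo sapiens) for inhibition, read by sulforhodamine B assay, with a stated time of 48 h; on this read-out higher numbers stand for weaker inhibition of growth and lower numbers for stronger inhibition of growth
compound 2, `COc1ccc(/C=C/C2CC=CC(=O)N2)cc1OC`, > 964 uM in this assay

Compound 1 sits at 102 uM in this assay. For compound 2 the result is a limit of the assay rather than a number, > 964 uM; this is the limit of > 964 uM in this assay, at which 1 of the 2 values shown sits. Among the compounds with values here, the two compounds share the dimethoxy-substituted styryl arm but differ in their core, and no single-point step between them is defined, so their two values only show that compound 1 is a measured number and compound 2 a limit.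

Compound 3, `COc1cc(/C=C/C2CC=CC(=O)N2)cc(OC)c1OC`, is not yet measured. It differs from compound 2 by methoxy in place of hydrogen on an aromatic carbon, so the trimethoxy pattern of compound 1 is carried onto the core of compound 2. Compound 2 gives only a limit in this assay, so the size of the step cannot be anchored from a measured pair; the expectation for compound 3 is a small step at most, estimated as an at least 1.6-fold lower number from compound 2 to compound 3 (0.20 log units; that floor lies within the scatter), with a real chance that a limit is reported again. The estimate for compound 3 in this assay is 600 uM, between 150 uM and 1500 uM.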

Compound 3, concentration for growth inhibition (reported as GI): > 864 uM
Compound 3 gave a limit, no number; the forecaster's own chance of this, stated with the estimate: 60%; at least 1.4-fold (0.15 log units) between middle value and limit.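

With methoxy in place of hydrogen on an aromatic carbon, ortho to a methoxy group, compound 3 still reads as a limit and not as a number in this assay, at > 864 uM. Both ends of this change are limits, so its step cannot be read, and the added methoxy does not bring the core of compound 2 to a measured value. Within the data shown here, with the trimethoxy pattern now held constant, the change of core alone gives an at least 8.4-fold higher number from compound 1 to compound 3 (0.92 log units; beyond the scatter), the first readable step, and it is the core change, not the added methoxy, that has a readable step so far.

As far as these compounds go, how far compound 2 and compound 3 lie past their limits stays open, and with it the full size of the step from the core change. Also open, from the compounds shown here alone, is whether another group on this aromatic carbon, such as an amine or a longer alkoxy chain, would give a measured number on the core of compound 2.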